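Series notes: dihydroxypropyl to cyanobenzyl on the shared core

A few compounds are considered here, and "the series" means these few. Any claim that something is new, unique, unknown or untested is made for them only; others in the source may bear on it.

Measured so far:
- compound 1, `Nc1nc(O)c2c(n1)n(C1OC(CO)[C@@H](O)[C@H]1O)c(=O)n2CC(O)CO`: 136%
- compound 2, `C=CCn1c(=O)n([C@@H]2O[C@H](CO)[C@H]3OC(=O)O[C@H]32)c2nc(N)nc(O)c21`: 50%

In a functional assay on the whole organism (B cells) with Mus musculus as the target (on this read-out lower numbers stand for smaller maximal responses and higher numbers for larger maximal responses), compound 1 gives 136% and stands highest of the two numbers measured. Its nearest neighbour is compound 2, which in this assay gives 50%, a gap that lies beyond the scatter of repeated measurements. Among the compounds with values here, compound 2 differs from compound 1 at more than one place, so no single-point step between measured compounds is available, and what separates the two values cannot be attributed to any one change.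

The compound still to be measured is compound 3, `N#Cc1ccc(Cn2c(=O)n(C3OC(CO)[C@@H](O)[C@H]3O)c3nc(N)nc(O)c32)cc1`. Relative to compound 1 the difference is 4-cyanophenyl in place of 1,2-dihydroxyethyl on a saturated chain carbon bound to an aromatic nitrogen; read one bond further out, 2,3-dihydroxypropyl gives way to 4-cyanobenzyl.

Within the data shown here, with no isolated step in hand, the expectation rests on the size of the change and on the two values shown. The step from compound 1 to compound 3 is expected to be downward and beyond the scatter, a number 46 percentage points lower from compound 1 to compound 3 (beyond the scatter). Compound 3 is accordingly estimated to reach 90% in this assay, within a range from 40% to 140%, the wide range reflecting that nothing measured yet carries a cyanobenzyl group.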

Compound 3, largest response reached (reported as maximal response), in percent of the reference or control that the assay uses: 50%
For compound 3 the middle estimate is 40 percentage points above the measured one; measured number inside the range.
By their numbers in this assay, from the lowest: compounds 2 and 3 (each within the scatter of the next); then compound 1.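

In this assay, the exchange of 2,3-dihydroxypropyl for 4-cyanobenzyl gives the series its first change in a single place, with a large step of a number 86 percentage points lower from compound 1 to compound 3 (beyond the scatter) on the shared core. The position on the saturated chain carbon bound to an aromatic nitrogen is therefore not indifferent to its substituent: with the rest of the structure unchanged, this one exchange moves the maximal response by more than the usual scatter. No measurement shown here gives a reason for the size or direction of this step.

This single exchange removes 1,2-dihydroxyethyl and brings in 4-cyanophenyl, so the compounds shown leave open whether the lower response follows the loss of the diol chain, the arrival of the aromatic ring or the presence of the nitrile. As far as these compounds go, a plain benzyl group, a propyl chain or a benzyl group carrying a carboxylic acid in place of the nitrile on the same core would bear on these possibilities, and the shape of the trend at this position remains unknown from one step.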